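The source may hold more compounds than are shown below. What is called first, only, known or untested is meant among the compounds shown, and "the series" means these compounds.

Compound 2 `O=C(O)c1cc(N2C(=O)C3=C(CCCC3)C2=O)ccc1Cl` carries a carboxy group on the shared core. In a functional assay on the whole organism for inhibition, with Scenedesmus acutus as the target (a higher number here means a weaker inhibitor, a lower number a stronger inhibitor), compound 2 yields no number, only (the limit of > 100000 nM in this assay, at which 1 of the 3 values shown sits). Compound 1 `O=C1C2=C(CCCC2)C(=O)N1c1ccc(Cl)cc1F`, with hydrogen at that aromatic carbon, gives 37.2 nM in this assay, and compound 3 `CCC(C)OC(=O)c1cc(N2C(=O)C3=C(CCCC3)C2=O)c(F)cc1Cl`, bearing sec-butoxycarbonyl, gives 60.3 nM. For the measured compounds named here, the only counted step, a 1.6-fold higher number from compound 1 to compound 3 (0.21 log units; within the scatter), shows that sec-butoxycarbonyl in place of hydrogen on an aromatic carbon leaves this assay essentially unchanged. Compound 4 `CCCCCOC(=O)c1cc(N2C(=O)C3=C(CCCC3)C2=O)ccc1Cl` differs from compound 2 by pentyl in place of hydrogen on an oxygen next to a carbonyl group. Going by the values given here, no measured step covers this change directly; compound 2 alone stands at the limit > 100000 nM. Compound 3, the sec-butoxycarbonyl analogue, gives 60.3 nM, so a large fall in number is expected for compound 4, an at least 1600-fold lower number from compound 2 to compound 4 (3.22 log units; beyond the scatter). Compound 4 is estimated at 60 nM, between 15 nM and 400 nM.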

Compound 4, half-maximal inhibitory concentration: 4470 nM
Beside the measured number, compound 4's estimate is 75-fold (1.87 log units) below it; the whole stated range lies below it.
By their numbers in this assay, from the lowest: compounds 1 and 3 (each within the scatter of the next); then compound 4. At a limit, above all of these: compound 2.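

In this assay, for the compounds shown here, pentyl in place of hydrogen on an oxygen next to a carbonyl group gives an at least 22-fold lower number from compound 2 to compound 4 (1.34 log units; beyond the scatter), the first step beyond the scatter, whereas the earlier counted step, made on an aromatic carbon, stayed within it. The true size of this change remains unknown, since the step is only a bound: the limit of > 100000 nM in this assay, at which 1 of the 4 values shown sits.

From the compounds shown here alone, whether a methyl group or a longer chain such as octyl on this oxygen would move the number further remains open. So does the effect of a primary amide in place of the carboxy group.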